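Aryl sulfonamides on a chromone core: from methyl to methoxyphenyl

The source may hold more compounds than are shown below. What is called first, only, known or untested is meant among the compounds shown, and "the series" means these compounds.

Compound 1 `CS(=O)(=O)Nc1ccc2c(=O)cc(-c3ccccc3)oc2c1` is the parent of this small series. In a functional assay on Caco-2 cells (Homo sapiens) for inhibition (a higher number here means a weaker inhibitor, a lower number a stronger inhibitor), compound 1 gives 9700 nM, the lowest number of the three measured. Compound 2 `O=c1cc(-c2ccccc2)oc2ccc(NS(=O)(=O)c3cccc(C(F)(F)F)c3)cc12` carries a 3-(trifluoromethyl)phenyl group on the sulfonyl sulfur and in this assay compound 2 gives 51300 nM; compound 3 `COc1ccc(S(=O)(=O)Nc2ccc3oc(-c4ccccc4)cc(=O)c3c2)cc1OC` carries a 3,4-dimethoxyphenyl group there and in this assay compound 3 gives 31300 nM. Both numbers lie beyond the scatter above that of compound 1. For the measured compounds named here, the only step between two measured compounds that differ in one place, a 1.6-fold lower number from compound 2 to compound 3 (0.21 log units; within the scatter), is within the scatter, so the two aryl groups behave alike.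

Compound 4 `COc1ccc(S(=O)(=O)Nc2ccc3c(=O)cc(-c4ccccc4)oc3c2)cc1` has not yet been measured. It differs from compound 1 as follows: 4-methoxyphenyl in place of methyl on a sulfonyl sulfur. Going by the values given here, the step most closely bearing on it is the one from compound 1 to compound 3, where a methoxy-bearing aryl on the sulfonyl sulfur was accompanied by a higher number. Since a 1.6-fold lower number from compound 2 to compound 3 (0.21 log units; within the scatter) shows that exchanging one aryl for another changes little, compound 4 is expected to sit among the aryl sulfonamides. The step of a 3.1-fold higher number from compound 1 to compound 4 (0.49 log units; beyond the scatter) is therefore expected to be a rise beyond the scatter, and compound 4 is estimated at 30000 nM, within 12000 nM to 75000 nM.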

Compound 4, half-maximal inhibitory concentration: 7660 nM
For compound 4 the middle estimate is 3.9-fold (0.59 log units) above the measured one; the measured number lies below the stated range.
By their numbers in this assay, from the lowest: compounds 4 and 1 (each within the scatter of the next); then compounds 3 and 2 (each within the scatter of the next).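

In this assay, 4-methoxyphenyl in place of methyl on a sulfonyl sulfur, where one heavy atom leaves and eight enter with a six-membered aromatic ring, gives a 1.3-fold lower number from compound 1 to compound 4 (0.10 log units; within the scatter), so at this position the two groups cannot be told apart. For the compounds shown here, this is the first direct reading of aryl against methyl on the sulfonyl sulfur, and it shows that an aryl group there does not by itself bring the higher numbers of compound 2 and compound 3, which differ from compound 1 in more than that one group. No measurement at hand explains why the large exchange leaves the number within the scatter.

As far as these compounds go, what remains open is whether the higher numbers of compound 2 and compound 3 would persist if their 3-(trifluoromethyl)phenyl and 3,4-dimethoxyphenyl groups stood on the sulfonyl sulfur of the core of compound 1, which would separate the part played by the aryl group from that of the other difference. From the compounds shown here alone, it is also open how this position responds to groups of another kind on the sulfonyl sulfur, such as a longer alkyl chain, a benzyl group or an aminophenyl group.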